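The source may hold more compounds than are shown below. What is called first, only, known or untested is meant among the compounds shown, and "the series" means these compounds.

Compound 1 `CCCCCCCCCCCCCCNC(=O)[C@@H]1CSC(c2ccc(OC)c(OC)c2)N1`: 1500 nM
Compound 2 `CCCCCCCCCCCCNC(=O)[C@@H]1CSC(c2ccc(NC(C)=O)cc2)N1`: 2400 nM

In a functional assay on cells (Homo sapiens) for antiproliferative activity, read by sulforhodamine B assay, with a stated time of 48 h (on this read-out higher numbers stand for weaker inhibition and lower numbers for stronger inhibition), compound 2 gives 2400 nM, within the scatter of compound 1 at 1500 nM. Compound 3 `CCCCCCCCCCCCCCNC(=O)[C@@H]1CSC(c2ccc(NC(C)=O)cc2)N1` differs from compound 2 by ethyl in place of hydrogen on a saturated chain carbon, ten or more bonds along the chain from an amide-type nitrogen, with ethyl in place of hydrogen on a saturated chain carbon, ten or more bonds along the chain from an amide-type nitrogen. Going by the values given here, no measured pair shows what this change does. In this assay, no shift beyond the scatter is expected, and no direction is favoured. The expected 1.3-fold lower number from compound 2 to compound 3 (0.12 log units; within the scatter) is therefore small. For compound 3 the estimated value is 1800 nM, with an expected range of 700 nM to 4500 nM.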

Compound 3, half-maximal inhibitory concentration: 2300 nM
The estimate for compound 3 lay 1.3-fold (0.11 log units) below the measured number; low and high end bracket the measured number.
By their numbers in this assay, from the lowest: compounds 1, 3 and 2 (each within the scatter of the next).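

In this assay, going by these compounds alone, ethyl in place of hydrogen on a saturated chain carbon, ten or more bonds along the chain from an amide-type nitrogen, gives a 1.0-fold lower number from compound 2 to compound 3 (0.02 log units; within the scatter), the first reading of a chain change on its own. With the chain held, 4-acetamidophenyl in place of 3,4-dimethoxyphenyl on a saturated ring carbon gives a 1.5-fold higher number from compound 1 to compound 3 (0.19 log units; within the scatter), so neither single change moves the number beyond the scatter. Nothing available explains either step.

Open, from the compounds shown here alone, is whether a much shorter chain, or one ending in an amine, would keep this level. Also open, going by these compounds, is what a carboxylic acid on the phenyl ring would do.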